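The source may report more compounds than this note shows. Statements on the series, on what has been measured and on what is new or still open speak of the compounds shown alone.

Measured compounds:
- compound 1, `CCNc1nc(SCC)nc2ncccc12`: 26200 nM
- compound 2, `CCCCCNc1nc(SCC)nc2ncccc12`: 5100 nM

In a functional assay on HT-29 cells (Homo sapiens) for cytotoxicity, read by neutral red uptake, with a stated time of 72 h (on this read-out lower numbers stand for stronger inhibition and higher numbers for weaker inhibition), compound 2 holds the lower of the two numbers shown; its only neighbour is compound 1, and the gap between them is a 5.1-fold lower number from compound 1 to compound 2 (0.71 log units; beyond the scatter). Compound 3, `CCCCCCNc1nc(SCC)nc2ncccc12`, differs from compound 2 by methyl in place of hydrogen on a saturated chain carbon, five bonds along the chain from a nitrogen on an aromatic ring. For the measured compounds named here, one measured step bears on this change: the chain lengthening from hydrogen to propyl, which gave a 5.1-fold lower number from compound 1 to compound 2 (0.71 log units; beyond the scatter) and ran beyond the scatter. The new change adds a single methyl at the far end of an already longer chain, so a further drop is expected, but a smaller one, and it may not clear the scatter. Compound 3 is therefore estimated at 3000 nM in this assay, within 1200 nM to 8000 nM. The expected step is a 1.7-fold lower number from compound 2 to compound 3 (0.23 log units; within the scatter).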

Compound 3, half-maximal inhibitory concentration: 22500 nM
Compound 3: the middle estimate sits 7.5-fold (0.88 log units) below what was measured; measured number above the stated range.
By their numbers in this assay, from the lowest: compound 2; then compounds 3 and 1 (each within the scatter of the next).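

In this assay, methyl in place of hydrogen at this place, five bonds along the chain from a nitrogen on an aromatic ring, gave a 4.4-fold higher number from compound 2 to compound 3 (0.64 log units; beyond the scatter) and so ran against the earlier step, showing that lengthening the chain does not lower the number without limit. Butyl in place of hydrogen, two bonds along the chain from that nitrogen, gave a 1.2-fold lower number from compound 1 to compound 3 (0.07 log units; within the scatter) and lies within the scatter, so of these three compounds only compound 2 stands apart from the others. Nothing available here accounts for this turn between neighbouring chain lengths.

A butyl chain on the nitrogen would show how the number moves on the way to compound 2. As far as these compounds go, whether a hydroxyl or an amine at the end of the hexyl chain of compound 3 would restore the lower number remains open as well.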